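Alkynyl to furanyl at the core: compound 4

This account rests on a few compounds, and the source may have more. Where it says the series, first, only, none or still open, it means among the compounds named here.

Of the compounds shown here, three on a shared core have been measured. Compound 1 `CCCC#Cc1cc([C@@H]2O[C@H](CO)[C@@H](O)[C@H]2O)n2ncnc(N)c12` carries a pent-1-yn-1-yl group, compound 2 `CCCCC#Cc1cc([C@@H]2O[C@H](CO)[C@@H](O)[C@H]2O)n2ncnc(N)c12` a hex-1-yn-1-yl group, and compound 3 `Nc1ncnn2c([C@@H]3O[C@H](CO)[C@@H](O)[C@H]3O)cc(-c3ccccc3)c12` a phenyl group. In a functional assay on LN-229 cells (Homo sapiens) for antiproliferative activity, with a stated time of 72 h (on this read-out higher numbers stand for weaker inhibition and lower numbers for stronger inhibition), compound 1 gives 40 nM. In this assay compound 2 gives 1000 nM, and compound 3 gives 75100 nM.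

Compound 2 stands second highest of the three numbers. Its nearest neighbour is compound 1, with a 25-fold higher number from compound 1 to compound 2 (1.40 log units; beyond the scatter); its furthest is compound 3, with a 75-fold higher number from compound 2 to compound 3 (1.88 log units; beyond the scatter).

Compound 4 `Nc1ncnn2c([C@@H]3O[C@H](CO)[C@@H](O)[C@H]3O)cc(-c3ccoc3)c12` differs from compound 2 in one place: furan-3-yl in place of hex-1-yn-1-yl on an aromatic carbon. Among the compounds with values here, the steps that bear on this change are the two in which an aromatic ring took the place of an alkynyl chain on the same aromatic carbon: a 75-fold higher number from compound 2 to compound 3 (1.88 log units; beyond the scatter) and a 1900-fold higher number from compound 1 to compound 3 (3.27 log units; beyond the scatter). Both were large and both ran toward weaker inhibition. Furan-3-yl is a five-membered aromatic ring with one hetero atom rather than a phenyl, so the size of the step is uncertain, but the same direction is expected, and the step from compound 2 to compound 4 is estimated as a 20-fold higher number from compound 2 to compound 4 (1.30 log units; beyond the scatter). Compound 4 is therefore expected to give 20000 nM, with a range from 3000 nM to 150000 nM.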

Compound 4, half-maximal inhibitory concentration: 1000 nM
Beside the measured number, compound 4's estimate is 20-fold (1.30 log units) above it; measured number below the stated range.
By their numbers in this assay, from the lowest: compound 1; then compounds 2 and 4 (each within the scatter of the next); then compound 3.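

In this assay, an aromatic ring on this aromatic carbon does not by itself carry the loss seen with phenyl: furan-3-yl in place of phenyl gives a clear gain (a 75-fold lower number from compound 3 to compound 4 (1.88 log units; beyond the scatter)), so the two rings differ widely at this position. Furan-3-yl in place of hex-1-yn-1-yl shows that a group with no triple bond can match the hexynyl compound here (no change at the digits printed from compound 2 to compound 4 (within the scatter)), yet the same ring in place of pent-1-yn-1-yl still falls well short (a 25-fold higher number from compound 1 to compound 4 (1.40 log units; beyond the scatter)), and compound 1 keeps the lowest number of the four. Nothing in hand accounts for the gap between furan-3-yl and phenyl, which remains an observation without an explanation.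

On these data alone, it remains open whether the result belongs to furan-3-yl alone or extends to other small rings at this position, such as thiophen-3-yl, furan-2-yl or a pyridine ring. Also open, as far as these compounds go, is how a shorter chain such as prop-1-yn-1-yl, or a chain ending in an amine or a hydroxyl group, would compare with the pent-1-yn-1-yl group of compound 1.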